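The source may report more compounds than this note shows. Statements on the series, on what has been measured and on what is new or still open speak of the compounds shown alone.

Measured compounds:
- compound 1 `O=[N+]([O-])c1ccc(-c2csc(N3N=C(c4ccc(N5CCCCC5)cc4)CC3c3ccc(Cl)cc3)n2)cc1`: > 100000 nM
- compound 2 `Clc1ccc(-c2csc(N3N=C(c4ccc(N5CCCCC5)cc4)CC3c3ccc(Cl)cc3)n2)cc1`: 46400 nM
- compound 3 `Clc1ccc(C2CC(c3ccc(N4CCCCC4)cc3)=NN2c2nc(-c3ccc(Br)cc3)cs2)cc1`: 39700 nM

In a functional assay on A549 cells (Homo sapiens) for antiproliferative activity, read by MTT assay, with a stated time of 72 h (a lower number here means a stronger inhibitor, a higher number a weaker inhibitor), compound 1 reaches only the limit of the assay, > 100000 nM, and no number is reported for it. Compound 2 gives 46400 nM in this assay. Compound 3 gives 39700 nM in this assay, which is the lowest of the two numbers shown, though its separation from compound 2 is slight: a 1.2-fold lower number from compound 2 to compound 3 (0.07 log units; within the scatter). Compound 4 `Clc1ccc(C2CC(c3ccc(N4CCCCC4)cc3)=NN2c2nc(-c3ccc4ccccc4c3)cs2)cc1` differs from compound 3 by naphthalen-2-yl in place of 4-bromophenyl on an aromatic carbon. Three measured steps change the same aryl group on the shared core: an at least 2.1-fold lower number from compound 1 to compound 2 (0.33 log units; beyond the scatter), an at least 2.5-fold lower number from compound 1 to compound 3 (0.40 log units; beyond the scatter) and a 1.2-fold lower number from compound 2 to compound 3 (0.07 log units; within the scatter). The first two move from a nitro group to a halogen and are at least modest; the halogen swap itself lies within the scatter. Going by these compounds, none of them places a naphthalen-2-yl at this position, so the new group is untested. Compound 4 is therefore expected to sit close to compound 3, with an estimated step of a 1.3-fold lower number from compound 3 to compound 4 (0.12 log units; within the scatter). Compound 4 is estimated at 30000 nM, within a range of 10000 nM to 100000 nM.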

Compound 4, half-maximal inhibitory concentration: > 100000 nM
Compound 4 gave a limit, no number; the forecaster's own chance of this, stated with the estimate: 15%; middle value at least 3.3-fold (0.52 log units) from the limit.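

In this assay, at this aromatic carbon next to the ring nitrogen, naphthalen-2-yl in place of 4-bromophenyl gives an at least 2.5-fold higher number from compound 3 to compound 4 (0.40 log units; beyond the scatter), and in place of 4-chlorophenyl it gives an at least 2.1-fold higher number from compound 2 to compound 4 (0.33 log units; beyond the scatter). The position therefore does not accept every aryl group alike: a group with neither a nitro nor a halogen substituent also leaves the measurable range, and among the four compounds only the 4-chlorophenyl and 4-bromophenyl groups give numbers. The step between compound 1 and compound 4 cannot be read, as both are limits and not numbers: the limit of > 100000 nM in this assay, at which 2 of the 4 values shown sit.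

The compounds shown do not separate the effect of adding a second ring from that of losing the halogen. Going by these compounds, whether an unsubstituted phenyl, a 4-fluorophenyl or a 4-methoxyphenyl here would give a number remains open.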